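The compounds below may be only part of what the source reports. "The series", "measured", "known", "first", "only" and "open" are said of these compounds alone.

Compound 1 `O=C(Nc1ccncc1)Nc1ccccc1F` gives 100 mg/kg in a functional assay on the whole organism with Mus musculus as the target, in the maximal electroshock model, with a stated time of 30 min; on this read-out lower numbers stand for an effect already at smaller amounts and higher numbers for an effect only at larger amounts of compound.
Compound 2 `CC(C)c1ccccc1NC(=O)Nc1ccncc1` gives 100 mg/kg in this assay.
Compound 3 `Nc1ccccc1NC(=O)Nc1ccncc1` gives > 300 mg/kg in this assay, which is a limit of the assay and not a number.

Compound 2 stands level with compound 1 within the scatter, shown by no change at the digits printed from compound 1 to compound 2 (within the scatter). Compound 3 sits at the limit of > 300 mg/kg in this assay, at which 1 of the 3 values shown sits. From compound 2 the change to the amino group is an at least 3.0-fold higher number from compound 2 to compound 3 (0.47 log units; beyond the scatter), and from compound 1 it is an at least 3.0-fold higher number from compound 1 to compound 3 (0.47 log units; beyond the scatter).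

Compound 4 `CC(C)c1cccc(C(C)C)c1NC(=O)Nc1ccncc1` is not yet measured. Its difference from compound 2 is isopropyl in place of hydrogen on an aromatic carbon.

Going by the values given here, no measured step adds an isopropyl where a hydrogen stood. The nearest comparison is no change at the digits printed from compound 1 to compound 2 (within the scatter), where an isopropyl in place of fluoro on an aromatic carbon left the number unchanged within the scatter. The amino steps concern a different group and do not bear directly on this change. The expectation is therefore a step of no change at the digits printed from compound 2 to compound 4 (within the scatter) in this assay, that is, no change beyond the scatter, with some allowance for a higher number. Compound 4 is estimated at 100 mg/kg in this assay, within a range from 50 mg/kg to 300 mg/kg.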

Compound 4, minimum effective dose: > 300 mg/kg
Compound 4: only a limit was reported (the forecaster's own chance of this, stated with the estimate: 20%); at least 3.0-fold (0.47 log units) between middle value and limit.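

In this assay, an isopropyl in place of hydrogen on an aromatic carbon, ortho to a large group and meta to an isopropyl group, gives an at least 3.0-fold higher number from compound 2 to compound 4 (0.47 log units; beyond the scatter). Until now, isopropyl had appeared only in place of fluoro, and that swap left the number unchanged within the scatter, so the shared core seemed able to carry one such group with no cost; adding a further isopropyl at this place shows that the core does not accept every added carbon group equally. The value of compound 4 is a limit of the assay and not a number, and compound 4 is the second compound to end at it: the limit of > 300 mg/kg in this assay, at which 2 of the 4 values shown sit.

The compounds shown leave open whether this higher number belongs to isopropyl in particular or would follow from any group at this place, since a smaller group such as methyl, or a chlorine atom, would be needed there to tell the two apart. They also cannot say how much higher the true number of compound 4 lies, nor what in the whole animal produces the change.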